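The source may report more compounds than this note shows. Statements on the series, on what has been measured and on what is new or still open speak of the compounds shown alone.

Of the compounds shown here, two of this set have been measured in a functional assay on Lewis lung carcinoma cells (Mus musculus) for antiproliferative activity, read by MTT assay, with a stated time of 24 h; on this read-out lower numbers stand for stronger inhibition and higher numbers for weaker inhibition. Compound 1 `C=CCc1cc(-c2ccc(OC)cc2)cc(CC=C)c1O` gives 60300 nM, and compound 2 `C=CC(C)(C)c1cc(-c2cccc([N+](=O)[O-])c2)ccc1O` gives 45100 nM. The two numbers lie within the usual scatter of each other, so compound 2 stands level with compound 1 on these data and neither can be set apart. Among the compounds with values here, the step under study leads from compound 2 to compound 3 `C=CCc1cc(-c2cccc([N+](=O)[O-])c2)ccc1O`. allyl in place of 1,1-dimethylprop-2-en-1-yl on an aromatic carbon No measured pair in this set carries this change, so nothing shows how it shifts the number. Within the data shown here, with only two measured compounds, both giving weak inhibition and no guide to the change, the expected step is a 1.0-fold lower number from compound 2 to compound 3 (0.00 log units; within the scatter), which does not go beyond the scatter. Compound 3 is therefore estimated at 45000 nM, with a range from 18000 nM to 110000 nM, the width reflecting the lack of any matched pair.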

Compound 3, half-maximal inhibitory concentration: > 100000 nM
Compound 3: a limit, no number; the forecaster's own chance of this, stated with the estimate: 5%; middle value at least 2.2-fold (0.34 log units) away from the limit.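

In this assay, allyl in place of 1,1-dimethylprop-2-en-1-yl on this aromatic carbon, ortho to a hydroxy group, gives an at least 2.2-fold higher number from compound 2 to compound 3 (0.34 log units; beyond the scatter). Within the data shown here, this is the first matched pair in the set, and it shows that the number responds to a change at this position, with the smaller group on the side of the higher number. Compound 3 reads > 100000 nM, which is a limit of the assay and not a number, so the step fixes only a lower bound on the size of the change: the limit of > 100000 nM in this assay, at which 1 of the 3 values shown sits.

The compounds shown leave open how a propyl chain, a longer chain or an amine on this aromatic carbon would read. They also leave open whether the step holds on any other core, as a single pair carries it.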